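The source may hold more compounds than are shown below. What is called first, only, known or untested is meant among the compounds shown, and "the series" means these compounds.

Measured in a functional assay on K562 cells (Homo sapiens) for cytotoxicity, read by trypan blue exclusion, with a stated time of 96 h; a lower number here means a stronger inhibitor, a higher number a weaker inhibitor:
- compound 1 `COc1cc(OC)c(/C=C/S(=O)(=O)Nc2ccc(OC)c(O)c2)c(OC)c1`: 15 nM
- compound 2 `COc1cc(OC)c(/C=C/S(=O)(=O)Nc2ccc(OC)c(OP(=O)(O)O)c2)c(OC)c1`: 7.5 nM
- compound 3 `COc1cc(OC)c(/C=C/S(=O)(=O)Nc2ccc(OC)c(N)c2)c(OC)c1`: 3 nM

Compound 3 has the lowest number of the three. Compound 4 `COC(=O)C(Nc1cc(NS(=O)(=O)/C=C/c2c(OC)cc(OC)cc2OC)ccc1OC)c1ccc(Cl)cc1` differs from it by (4-chlorophenyl)(methoxycarbonyl)methyl in place of hydrogen on a nitrogen on an aromatic ring. Among the measured compounds shown here, no measured step places a group on that nitrogen, so the evidence is indirect. The closest guides are a 5.0-fold lower number from compound 1 to compound 3 (0.70 log units; beyond the scatter) and a 2.5-fold lower number from compound 2 to compound 3 (0.40 log units; beyond the scatter), both modest, and a 2.0-fold lower number from compound 1 to compound 2 (0.30 log units; within the scatter), which lies within the scatter. A modest move towards a higher number in this assay is therefore expected, at the larger end of those steps. The estimated step is a 6.7-fold higher number from compound 3 to compound 4 (0.82 log units; beyond the scatter). Compound 4 is expected at 20 nM, with an estimated range of 4 nM to 150 nM.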

Compound 4, half-maximal inhibitory concentration: 2500 nM
Beside the measured number, compound 4's estimate is 130-fold (2.10 log units) below it; measured number above the stated range.
By their numbers in this assay, from the lowest: compound 3; then compounds 2 and 1 (each within the scatter of the next); then compound 4.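

In this assay the nitrogen on an aromatic ring does not accept every group: (4-chlorophenyl)(methoxycarbonyl)methyl in place of hydrogen gives an 830-fold higher number from compound 3 to compound 4 (2.92 log units; beyond the scatter) and so reverses the gain seen with the amino group. Among the compounds shown here, this is the only large step in the set, as the earlier steps were modest or within the scatter. Nothing measured here bears on why the number rises.

The compounds shown leave open whether the rise belongs to the whole group or to one part of it, the 4-chlorophenyl ring or the methoxycarbonyl. They also leave open how a single methyl on that nitrogen, or a carboxylic acid in place of the methoxycarbonyl, would read.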